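Cyclopropylmethyl variant of the amide-nitrogen substituent in the mGlu2 series

This account rests on a few compounds, and the source may have more. Where it says the series, first, only, none or still open, it means among the compounds named here.

Measured compounds and their maximal responses:
compound 1 `Cc1cc(Oc2ccc(-c3ccn(CCC(C)C)c(=O)c3C#N)cc2)ccn1`, 266%
compound 2 `Cc1cc(Oc2ccc(-c3ccn(CC4CCC4)c(=O)c3C#N)cc2)ccn1`, 233%
compound 3 `CCCCn1ccc(-c2ccc(Oc3ccnc(C)c3)cc2)c(C#N)c1=O`, 243%

In a functional assay on CHO cells for positive allosteric modulation of metabotropic glutamate receptor 2 (Homo sapiens), read by scintillation counting and GTPgammaS binding, with a stated time of 30 min (a lower number here means a smaller maximal response, a higher number a larger maximal response), compound 3 stands second highest of the three; its nearest neighbour is compound 2, within the scatter, and its furthest is compound 1, beyond the scatter. Compound 4 `Cc1cc(Oc2ccc(-c3ccn(CC4CC4)c(=O)c3C#N)cc2)ccn1` differs from compound 3 by cyclopropyl in place of propyl on a saturated chain carbon bound to an aromatic nitrogen.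

For the measured compounds named here, two measured steps bear on this change. The step of a number 10 percentage points higher from compound 2 to compound 3 (within the scatter) shows that exchanging a ring for a chain at this position left the maximal response within the scatter. The step of a number 33 percentage points lower from compound 1 to compound 2 (beyond the scatter) shows a large drop when a ring replaced a branched chain. Going by the values given here, putting a ring in place of a chain has therefore either left the number unchanged or lowered it; no step has raised it. For compound 4 a small downward step or none beyond the scatter is expected, a number 11 percentage points lower from compound 3 to compound 4 (beyond the scatter). Compound 4 is estimated to give 232%, within a range from 200% to 265%.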

Compound 4, largest response reached (Emax), in percent of the reference or control that the assay uses: 199%
Beside the measured number, compound 4's estimate is 33 percentage points above it, outside the stated range (below it).
By their numbers in this assay, from the lowest: compound 4; then compounds 2 and 3 (each within the scatter of the next); then compound 1.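

In this assay, the cyclopropyl group brings a large fall against the chain, a number 44 percentage points lower from compound 3 to compound 4 (beyond the scatter), and also against the neighbouring ring, a number 34 percentage points lower from compound 2 to compound 4 (beyond the scatter), so ring size matters at this position, whereas compound 2 and compound 3, with a ring and a chain, stood within the scatter of each other. The widest gap in the series, a number 67 percentage points lower from compound 1 to compound 4 (beyond the scatter), shows that this one position spans a larger range of maximal response than compound 1, compound 2 and compound 3 alone suggested. Nothing on hand accounts for these steps.

The compounds shown leave open where a longer chain such as pentyl, or a cyclopentylmethyl group, would fall in this order. They also leave open whether the same ranking holds when the core of compound 1 is changed elsewhere.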